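This account rests on a few compounds, and the source may have more. Where it says the series, first, only, none or still open, it means among the compounds named here.

Three measured compounds share one core and differ only in the group on the aromatic ring of the benzylamide. Compound 1 `CCc1ccccc1N(CC(=O)NCc1ccccc1)S(=O)(=O)c1ccc(C)cc1` carries hydrogen there and, in a functional assay on CHO-K1 cells for antagonist activity at prostaglandin E2 receptor EP1 subtype (Homo sapiens), read by FLIPR and calcium flux (a lower number here means a stronger inhibitor, a higher number a weaker inhibitor), compound 1 gives 224 nM. Compound 2 `CCc1ccccc1N(CC(=O)NCc1ccc(Cl)cc1)S(=O)(=O)c1ccc(C)cc1` carries chloro at that carbon; in this assay compound 2 gives 11.5 nM. Compound 3 `CCc1ccccc1N(CC(=O)NCc1ccc(C(F)(F)F)cc1)S(=O)(=O)c1ccc(C)cc1` carries trifluoromethyl; in this assay compound 3 gives 209 nM. The two substitutions behaved quite differently: a 19-fold lower number from compound 1 to compound 2 (1.29 log units; beyond the scatter), whereas a 1.1-fold lower number from compound 1 to compound 3 (0.03 log units; within the scatter), and an 18-fold higher number from compound 2 to compound 3 (1.26 log units; beyond the scatter). Compound 2 thus stands lowest of the three numbers, with compound 1 and compound 3 both well beyond the scatter above it.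

Compound 4 `Cc1ccc(S(=O)(=O)N(CC(=O)NCc2ccc(Cl)cc2)c2cccnc2C)cc1` keeps the chloro-bearing benzylamide of compound 2 and alters a different place on the core: 2-methylpyridin-3-yl in place of 2-ethylphenyl on a sulfonamide nitrogen. For the measured compounds named here, none of the measured steps touches the sulfonamide nitrogen; all three concern the benzylamide ring, so they give no direct guide to this exchange, and the record holds nothing on a pyridine at this position. In this assay the change is expected to bring a modest shift at most, a 3.0-fold higher number from compound 2 to compound 4 (0.48 log units; beyond the scatter). Compound 4 is therefore estimated to give about 35 nM, within a range from 8 nM to 150 nM.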

Compound 4, inhibition constant: 676 nM
Compound 4: middle estimate off by 19-fold (1.29 log units), on the low side; measured number above the stated range.
By their numbers in this assay, from the lowest: compound 2; then compounds 3 and 1 (each within the scatter of the next); then compound 4.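

In this assay, the group on the sulfonamide nitrogen turns out to matter strongly: 2-methylpyridin-3-yl in place of 2-ethylphenyl gives a 59-fold higher number from compound 2 to compound 4 (1.77 log units; beyond the scatter). The earlier steps shown here concerned only the benzylamide ring, and this one shows that keeping the chloro group of compound 2 there does not preserve its low number once the group on the sulfonamide nitrogen changes. The exchange brings in a ring nitrogen, counted as a hydrogen-bond acceptor, and replaces ethyl with methyl, but nothing available gives a reason for the size of the step.

The compounds shown leave open which of those two differences carries the step, a question that a 2-methylphenyl or a 2-ethylpyridin-3-yl group on the same nitrogen, with the benzylamide of compound 2 unchanged, would separate. They also leave open whether the same exchange would act alike with hydrogen or trifluoromethyl on the benzylamide ring, and how other groups on this nitrogen, such as a 2-propylphenyl with its longer chain, would compare.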